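Thiophene for methoxyphenyl on the methylated uracil nucleoside

The source may hold more compounds than are shown below. What is called first, only, known or untested is meant among the compounds shown, and "the series" means these compounds.

Measured compounds:
compound 1 `CCS[C@@H]1[C@H](SCC)[C@@H](Cn2cc(-c3ccc(OC)cc3)nn2)O[C@H]1n1ccc(=O)[nH]c1=O`: 27700 nM
compound 2 `CCS[C@@H]1[C@H](SCC)[C@@H](Cn2cc(-c3cccs3)nn2)O[C@H]1n1ccc(=O)[nH]c1=O`: >= 100000 nM
compound 3 `CCS[C@@H]1[C@H](SCC)[C@@H](Cn2cc(-c3ccc(OC)cc3)nn2)O[C@H]1n1cc(C)c(=O)[nH]c1=O`: 66000 nM

Three compounds of the series have been run in a functional assay on HeLa cells (Homo sapiens) for cytotoxicity, read by MTT assay, with a stated time of 72 h; on this read-out higher numbers stand for an effect only at larger amounts of compound and lower numbers for an effect already at smaller amounts. Compound 1 gives 27700 nM. Compound 3 gives 66000 nM, the higher of the two numbers; the step is a 2.4-fold higher number from compound 1 to compound 3 (0.38 log units; beyond the scatter). Compound 2 sits at a limit of this assay, >= 100000 nM, so no number is known for it; see (the limit of >= 100000 nM in this assay, at which 1 of the 3 values shown sits).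

Compound 4 `CCS[C@@H]1[C@H](SCC)[C@@H](Cn2cc(-c3cccs3)nn2)O[C@H]1n1cc(C)c(=O)[nH]c1=O` is not yet measured. It differs from compound 3 by one change: thiophen-2-yl in place of 4-methoxyphenyl on an aromatic carbon. The same exchange has been made once before, from compound 1 to compound 2, where it gave an at least 3.6-fold higher number from compound 1 to compound 2 (0.55 log units; beyond the scatter), with compound 2 ending at the limit. Compound 3 already starts from the higher number of the two known, so the same exchange on the methylated core is expected to carry compound 4 beyond the limit of this assay, and most likely only a limit will be reported. The step from compound 3 to compound 4 is therefore expected to be a 3.0-fold higher number from compound 3 to compound 4 (0.48 log units; beyond the scatter), upward. For compound 4 in this assay the estimate is 200000 nM, with a range of 80000 nM to 500000 nM.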

Compound 4, half-maximal effective concentration: 54900 nM
The estimate for compound 4 lay 3.6-fold (0.56 log units) above the measured number; the whole stated range lies above it.
By their numbers in this assay, from the lowest: compounds 1, 4 and 3 (each within the scatter of the next, the first and the last beyond it). At a limit, above all of these: compound 2.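

In this assay the exchange of 4-methoxyphenyl for thiophen-2-yl does not give one fixed step: on the core of compound 3 it gives a 1.2-fold lower number from compound 3 to compound 4 (0.08 log units; within the scatter), and the two steps part: the same change on two cores in this assay, an at least 3.6-fold higher number (0.55 log units; beyond the scatter) from compound 1 to compound 2 and a 1.2-fold lower number (0.08 log units; within the scatter) from compound 3 to compound 4, at least 4.3-fold (0.63 log units) apart, beyond the scatter of two such steps

The exchange of hydrogen for methyl likewise gives no single step across the two groups, with an at least 1.8-fold lower number from compound 2 to compound 4 (0.26 log units; that floor lies within the scatter) in the thiophen-2-yl pair against a higher number in the 4-methoxyphenyl pair: the same change on two cores in this assay, a 2.4-fold higher number (0.38 log units; beyond the scatter) from compound 1 to compound 3 and an at least 1.8-fold lower number (0.26 log units; that floor lies within the scatter) from compound 2 to compound 4, at least 4.3-fold (0.63 log units) apart, beyond the scatter of two such steps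

The size of both gaps rests on compound 2, whose value is a limit and not a number: the limit of >= 100000 nM in this assay, at which 1 of the 4 values shown sits.

Open, as far as these compounds go, is whether an amine or a carboxylic acid in place of thiophen-2-yl on this aromatic carbon would also give a number close to those of compound 3 and compound 4 on the methylated core. Also open, from the compounds shown here alone, is whether a longer chain in place of the methyl would show the same dependence on the group carried by the five-membered aromatic ring with 3 nitrogen.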